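Amide aryl swap on the chalcone series: thiophene to dichlorophenyl

A few compounds are considered here, and "the series" means these few. Any claim that something is new, unique, unknown or untested is made for them only; others in the source may bear on it.

Going by the values given here, compound 3 `COc1cc(/C=C/C(=O)c2cccc(NC(=O)c3cccs3)c2)ccc1O` gives the only number in the set, 3.98 ug/mL in a functional assay on Vero cells (Chlorocebus sabaeus) for inhibition; a higher number here means a weaker inhibitor, a lower number a stronger inhibitor. Compound 1 `COc1cc(/C=C/C(=O)c2cccc(NC(=O)c3ccc(Cl)c(Cl)c3)c2)ccc1O` reaches only the limit > 50 ug/mL. Compound 2 `CCOC(=O)C(=O)Nc1cccc(C(=O)/C=C/c2ccc(O)c(OC)c2)c1` likewise stops at the limit > 50 ug/mL. The steps of an at least 12-fold lower number from compound 1 to compound 3 (1.09 log units; beyond the scatter) and an at least 12-fold lower number from compound 2 to compound 3 (1.09 log units; beyond the scatter) are both large, and the step that the two limits leave unreadable from compound 1 to compound 2 cannot be read because of the limit of > 50 ug/mL in this assay, at which 2 of the 3 values shown sit. Compound 4 `COc1cc(/C=C/C(=O)c2cccc(NC(=O)c3c(Cl)cccc3Cl)c2)ccc1O` differs from compound 3 by 2,6-dichlorophenyl in place of thiophen-2-yl on a carbonyl carbon. Among the compounds with values here, only the step from compound 1 to compound 3 bears on this, since it also trades a dichlorophenyl for thiophen-2-yl; its reverse is expected here, so a rise in this assay is expected, a 7.5-fold higher number from compound 3 to compound 4 (0.88 log units; beyond the scatter). Compound 4 is expected at 30 ug/mL, between 6 ug/mL and 50 ug/mL, quite possibly again only a limit.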

Compound 4, half-maximal inhibitory concentration: 2.48 ug/mL
Compound 4: the middle estimate sits 12-fold (1.08 log units) above what was measured, outside the stated range (below it).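

In this assay a dichlorophenyl group on this carbonyl carbon is compatible with activity: 2,6-dichlorophenyl stands level with thiophen-2-yl, with a 1.6-fold lower number from compound 3 to compound 4 (0.21 log units; within the scatter). Where the chlorines sit on the ring therefore matters, not merely their presence, as an at least 20-fold lower number from compound 1 to compound 4 (1.30 log units; beyond the scatter) shows, and the ethoxycarbonyl comparison gives an at least 20-fold lower number from compound 2 to compound 4 (1.30 log units; beyond the scatter). Both large steps are only bounds: the limit of > 50 ug/mL in this assay, at which 2 of the 4 values shown sit.

Still open, going by these compounds, is whether a single chlorine, as in 2-chlorophenyl, keeps this level on the same carbonyl carbon. Also open, on these data alone, is how a saturated cyclohexyl ring or a phenyl ring carrying an amine or a carboxylic acid would fare there.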